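The source may report more compounds than this note shows. Statements on the series, on what has been measured and on what is new or still open speak of the compounds shown alone.

Compound 1, `O=C(/C=C/c1ccc(F)c(Cl)c1)c1ccc(B(O)O)cc1`, in a functional assay on MDA-MB-435 cells (Homo sapiens) for inhibition (on this read-out higher numbers stand for weaker inhibition and lower numbers for stronger inhibition), gives 16000 nM.
Compound 2, `O=C(/C=C/c1ccc(F)c(F)c1)c1ccc(B(O)O)cc1`, in this assay gives 8800 nM.

On the numbers shown, compound 2 stands at the lowest of the two, with compound 1 as its only neighbour; the step of a 1.8-fold lower number from compound 1 to compound 2 (0.26 log units; within the scatter) lies within the scatter, so the two compounds cannot be told apart on these data. Compound 3, `O=C(/C=C/c1ccc(F)c(Br)c1)c1ccc(B(O)O)cc1`, has not yet been measured in this assay. It differs from compound 2 in one place: bromo in place of fluoro on an aromatic carbon. Among the measured compounds shown here, the only measured step that bears on this change is the exchange of one halogen for another on the same aromatic carbon, a 1.8-fold lower number from compound 1 to compound 2 (0.26 log units; within the scatter), which stayed within the scatter. A single step of that size gives no ground to expect a larger shift in this assay for the next halogen exchange. For compound 3 the estimate is therefore 13000 nM, with a range from 5500 nM to 32000 nM. This corresponds to an expected step of a 1.5-fold higher number from compound 2 to compound 3 (0.17 log units; within the scatter), which would not go beyond the scatter.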

Compound 3, half-maximal inhibitory concentration: 8800 nM
Estimate against measurement, compound 3: 1.5-fold (0.17 log units) above; low and high end bracket the measured number.
By their numbers in this assay, from the lowest: compounds 2, 3 and 1 (each within the scatter of the next).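

With bromo on this aromatic carbon, ortho to a fluoro group, fluoro, chloro and bromo have now all been read at the same place in this assay: putting bromo in place of fluoro gives (no change at the digits printed from compound 2 to compound 3 (within the scatter)), and putting bromo in place of chloro gives (a 1.8-fold lower number from compound 1 to compound 3 (0.26 log units; within the scatter)). The earlier pair offered a single halogen exchange, whereas the three compounds now show that no exchange among these halogens at this position goes beyond the usual scatter, so they cannot be put in any order on these data. No evidence is at hand that would explain this flat result.

As far as these compounds go, it remains open whether a group that is not a halogen on this same carbon, such as a methoxy group, an amine or a carboxylic acid, would give a number clearly apart from these three. Also open, from the compounds shown here alone, is how much the fluoro group shared by all three compounds, or the boronic acid of the shared core, contributes, as neither of them varies here.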